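The compounds below may be only part of what the source reports. "The series", "measured", "known", "first", "only" and "open" are said of these compounds alone.

Working notes on the series in a functional assay on SF-268 cells (Homo sapiens) for inhibition, read by sulforhodamine B assay, with a stated time of 48 h, tested at 10 uM; a lower number here means a stronger effect, a higher number a weaker effect of the compound at the concentration tested. Compound 1 `COc1cc(Cl)cc(-c2nn(-c3cccc(NC(=O)c4ccc(Cl)c(Cl)c4)c3)cc2-c2ccncc2)c1` gives 82.4% in this assay. Compound 2 `O=C(Nc1cccc(-n2cc(-c3ccncc3)c(-c3cc(O)cc(Cl)c3)n2)c1)Nc1ccc(Cl)c(C(F)(F)F)c1` gives 42.1% in this assay. Compound 3 `O=C(Nc1cccc(-n2cc(-c3ccncc3)c(-c3cc(O)cc(Cl)c3)n2)c1)Nc1ccc(Cl)c(Cl)c1` gives 16.2% in this assay. Among these three numbers compound 2 stands second highest: the step of a number 25.9 percentage points lower from compound 2 to compound 3 (beyond the scatter) is beyond the scatter, and compound 1 lies above compound 2 by a gap that is also beyond the scatter.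

Compound 4 `COc1cc(Cl)cc(-c2nn(-c3cccc(NC(=O)Nc4ccc(Cl)c(C(F)(F)F)c4)c3)cc2-c2ccncc2)c1` has not yet been measured in this assay. It differs from compound 2 in one place: methyl in place of hydrogen on an oxygen on an aromatic ring. Among the measured compounds shown here, no measured step bears on this change. For the measured compounds named here, the single measured step, a number 25.9 percentage points lower from compound 2 to compound 3 (beyond the scatter), concerns chloro in place of trifluoromethyl on an aromatic carbon and leaves the hydroxy untouched. Compound 1 carries the methoxy but differs from compound 2 in more than one place, so its value says nothing on its own about the methyl. With nothing to anchor a direction, no step beyond the scatter is expected, and the range must stay wide. For compound 4 the expected value in this assay is 55%, estimated to fall between 25% and 85%. The expected step is therefore a number 12.9 percentage points higher from compound 2 to compound 4 (beyond the scatter).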

Compound 4, a percentage reported as activity, at one concentration (the size of the read-out at that concentration, not a potency): 22.9%
Beside the measured number, compound 4's estimate is 32.1 percentage points above it, and the stated range ends above it.
By their numbers in this assay, from the lowest: compounds 3 and 4 (each within the scatter of the next); then compound 2; then compound 1.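

In this assay the position on the 3-chloro-5-hydroxyphenyl ring now has its first measured change: hydroxy to methoxy gives a number 19.2 percentage points lower from compound 2 to compound 4 (beyond the scatter), so a free hydroxy is not needed for a low number here. With the methoxy in both compounds, (4-chloro-3-(trifluoromethyl)phenyl)amino in place of 3,4-dichlorophenyl on the carbonyl carbon gives a number 59.5 percentage points lower from compound 1 to compound 4 (beyond the scatter), so the methoxy alone does not set the high number of compound 1. Nothing available explains why either change moves the number in this direction.

As far as these compounds go, whether the hydroxy to methoxy step carries over to the 3,4-dichlorophenyl partner of compound 3 stays open. So does the effect of a longer chain on that oxygen, such as ethyl, or of an amine in place of the hydroxy.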